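The compounds below may be only part of what the source reports. "The series", "measured", "known", "first", "only" and "open" are said of these compounds alone.

Measured so far in an ADME assay on microsomes from liver (Mus musculus) for metabolic stability, read by LC-MS, with a stated time of 30 min, tested at 1 uM; a lower number here means that less of the compound is left, a higher number that more of the compound is left:
- Compound 1 `O=C(NCc1ccc(S(=O)(=O)N2CCCCC2)cc1)c1ccn2ccnc2c1`: "not determined" (no result reported)
- Compound 2 `O=C(NCc1ccc(S(=O)(=O)N2CCCCC2)cc1)c1cc2cccnc2s1`: "below limit of detection" (no number reported)
- Compound 3 `O=C(NCc1ccc(S(=O)(=O)N2CCCCC2)cc1)c1ccn2cncc2c1`: 1%

Only one of these entries is a number. Compound 1 has no reported result. For compound 2, the entry reads "below limit of detection" (no number reported). Compound 3 therefore stands alone with 1%, and this is close to the bottom of a scale that cannot go under zero.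

The next compound is compound 4 `O=C(NCc1ccc(S(=O)(=O)N2CCCCC2)cc1)c1cc2ccncc2o1`. It keeps the rest of the molecule and differs only in one group: a group of 9 heavy atoms (7 carbon, 1 nitrogen, 1 oxygen; one five-membered aromatic ring with 1 hetero atom, one six-membered aromatic ring with 1 hetero atom) in place of a group of 9 heavy atoms (7 carbon, 2 nitrogen; one five-membered aromatic ring with 2 hetero atoms, one six-membered aromatic ring with 1 hetero atom), on a carbonyl carbon. For the measured compounds named here, no measured pair in this set shows what a swap of this kind does, so the expectation is necessarily loose. With so little room to fall, any change is more likely upward, but no move beyond the usual scatter is expected in this assay. The estimated change is a number 2 percentage points higher from compound 3 to compound 4 (within the scatter). For compound 4 the expected value is 3%, with an estimated range from 0% to 15%.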

Compound 4, percent of the compound remaining: 0.14%
For compound 4 the middle estimate is 2.9 percentage points above the measured one, and the stated range covers the measured number.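

In this assay, for the compounds shown here, the swap on the carbonyl carbon gives the first step in this set that can be read as a single change (a number 0.9 percentage points lower from compound 3 to compound 4 (within the scatter)). Placing the group with one hetero atom in its five-membered aromatic ring in place of the group with two therefore shows no move beyond the usual scatter, and both compounds sit near the bottom of the scale. Nothing measured here accounts for this result.

The compounds shown leave open whether a group of a different kind on this carbonyl carbon, such as a plain phenyl ring or a ring carrying a carboxylic acid, would leave more compound after the incubation. They also leave open how much the rest of the molecule, the same in all four compounds, contributes to these low numbers.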